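The source may hold more compounds than are shown below. What is called first, only, known or untested is meant among the compounds shown, and "the series" means these compounds.

Of the compounds shown here, three have so far been measured in an assay on cells for agonist activity at ecdysone receptor (Bombyx mori), read by a luciferase reporter, with a stated time of 24 h; a lower number here means that less compound is needed, a higher number that more compound is needed for the effect. Compound 1 `CC(C)(C)N(NC(=O)c1ccc(Br)cc1)C(=O)c1ccccc1Cl` gives 33.9 nM, compound 2 `CCOc1ccccc1C(=O)N(NC(=O)c1ccc(CC)cc1)C(C)(C)C` gives 2880 nM, and compound 3 `CCCCCC(=O)N(NC(=O)c1cc(C)cc(C)c1)C(C)(C)C` gives 8710 nM. Compound 3 stands highest of the three: its nearest neighbour is compound 2, while the gap to compound 1 is far wider, and both gaps lie beyond the scatter. Compound 4 `Cc1cc(C)cc(C(=O)NN(C(=O)CCC(C)C)C(C)(C)C)c1` has not yet been measured. It differs from compound 3 in one place: isopropyl in place of propyl on a saturated chain carbon, two bonds along the chain from a carbonyl carbon. Among the measured compounds shown here, no measured pair shows a change of this kind, so its size cannot be read from the data. The expectation is a small step in a 1.2-fold lower number from compound 3 to compound 4 (0.09 log units; within the scatter), not clearly beyond the scatter, in either direction. Compound 4 is estimated at 7000 nM, within 2000 nM to 25000 nM.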

Compound 4, half-maximal effective concentration: 14500 nM
Beside the measured number, compound 4's estimate is 2.1-fold (0.32 log units) below it, within the range that was stated.
By their numbers in this assay, from the lowest: compound 1; then compound 2; then compounds 3 and 4 (each within the scatter of the next).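

In this assay, placing isopropyl in place of propyl on a saturated chain carbon, two bonds along the chain from a carbonyl carbon, gives a 1.7-fold higher number from compound 3 to compound 4 (0.22 log units; within the scatter). Among the compounds shown here, this is the first measured pair that differs in one place, and it shows that this rearrangement of the same carbon atoms produces no change that can be separated from the scatter. No supporting data are available to explain this result. On these data alone, whether an amine, a carboxylic acid or a longer chain in place of the isopropyl would move the number beyond the scatter remains open. A single pair also cannot show whether the same change would give a similar result on another core.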